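This account rests on a few compounds, and the source may have more. Where it says the series, first, only, none or still open, it means among the compounds named here.

Measured so far:
compound 1 `COc1ccc(F)cc1Nc1cc(NC(=O)Nc2c(Cl)cccc2Cl)ncn1` — 38.1%
compound 2 `COc1cc(NC(=O)Nc2cc(Nc3ccc(F)c(Cl)c3)ncn2)cc(OC)c1` — 25.5%

Two compounds of this series have been run in a functional assay on NCI-H520 cells (Homo sapiens) for inhibition, read by MTT assay, with a stated time of 48 h, tested at 10 uM; a higher number here means more inhibition at the concentration tested (going by the name of the read-out), a lower number less inhibition. Compound 1 gives 38.1%. Going by the values given here, compound 2 gives 25.5%, the lower of the two numbers, and its gap to compound 1 lies beyond the usual scatter; the two structures differ in more than one place, so no single step is recorded between them.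

The next compound, compound 3 `COc1cc(NC(=O)Nc2cc(Nc3cc(F)ccc3OC)ncn2)cc(OC)c1`, remains to be measured in this assay. It keeps the urea side of compound 2 and changes only the aryl on the amine nitrogen: 5-fluoro-2-methoxyphenyl in place of 3-chloro-4-fluorophenyl on a nitrogen on an aromatic ring. The group that enters is the same one carried by compound 1, though compound 1 differs from compound 3 on the urea side as well, so its value is no direct guide.

Among the compounds with values here, with no step of this kind recorded, the step from compound 2 to compound 3 is expected to be small, of about a number 5.5 percentage points higher from compound 2 to compound 3 (within the scatter) in the direction of more inhibition, and possibly within the scatter. For compound 3 the estimated value in this assay is 31%, with a range from 16% to 46%.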

Compound 3, a percentage reported as inhibition, at one concentration (the size of the read-out at that concentration, not a potency): 38%
Beside the measured number, compound 3's estimate is 7 percentage points below it; the measured number falls inside the stated range.
By their numbers in this assay, from the lowest: compound 2; then compounds 3 and 1 (each within the scatter of the next).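

In this assay, going by these compounds alone, with the 3,5-dimethoxyphenyl side of the urea held constant, the first single-place comparison on the nitrogen on an aromatic ring gives a number 12.5 percentage points higher from compound 2 to compound 3 (beyond the scatter) for 5-fluoro-2-methoxyphenyl in place of 3-chloro-4-fluorophenyl, so the choice of aryl at this position can move the read-out beyond the scatter. With 5-fluoro-2-methoxyphenyl held constant, 3,5-dimethoxyphenyl in place of 2,6-dichlorophenyl on an amide-type nitrogen gives a number 0.1 percentage points lower from compound 1 to compound 3 (within the scatter) and thus does not separate this pair. No measurement shown offers an explanation for either step.

The two aryl groups on the amine nitrogen differ in more than one substituent, so these compounds do not show whether the step from 3-chloro-4-fluorophenyl goes with the entering methoxy, the loss of chlorine or the altered fluorine placement. On these data alone, it also remains open whether the step carries over to the 2,6-dichlorophenyl urea, and how a dimethylamino group or a carboxylic acid in place of the methoxy would read in this assay at the single concentration tested.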